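An Ethoxy Extension Tested on a Second Core

This account rests on a few compounds, and the source may have more. Where it says the series, first, only, none or still open, it means among the compounds named here.

Compound 1, `COc1ccc(NC(=O)c2cn(-c3ccccc3)nc2-c2ccccc2)cc1`, gives 1710 nM in a functional assay on MCF7 cells (Homo sapiens) for cytotoxicity, read by MTT assay, with a stated time of 48 h; a higher number here means a weaker inhibitor, a lower number a stronger inhibitor.
Compound 2, `CCOc1ccc(NC(=O)c2cn(-c3ccccc3)nc2-c2ccccc2)cc1`, gives 880 nM in this assay.
Compound 3, `COc1ccc(NC(=O)c2cn(-c3ccccc3)nc2-c2ccc(OC)cc2)cc1`, gives 1770 nM in this assay.

Compound 4, `CCOc1ccc(NC(=O)c2cn(-c3ccccc3)nc2-c2ccc(OC)cc2)cc1`, has not yet been measured in this assay. It differs from compound 3 by methyl in place of hydrogen on a saturated chain carbon bound to an oxygen on an aromatic ring. The same change has been made once before among these compounds, from compound 1 to compound 2, as methyl in place of hydrogen on a saturated chain carbon bound to an oxygen on an aromatic ring, and there it produced a 1.9-fold lower number from compound 1 to compound 2 (0.29 log units; within the scatter). The two cores on which the change is made differ by methoxy in place of hydrogen on an aromatic carbon, and that difference gave a 1.0-fold higher number from compound 1 to compound 3 (0.01 log units; within the scatter), so the two cores sit close together in this assay. The place of the change reads the same, word for word, in both pairs, so it is treated as the same change. For the measured compounds named here, compound 4 is expected to show a 1.8-fold lower number from compound 3 to compound 4 (0.25 log units; within the scatter) because a 1.9-fold lower number from compound 1 to compound 2 (0.29 log units; within the scatter) is the only guide available and the cores behave alike. Compound 4 is accordingly estimated at 1000 nM in this assay, with an expected range from 500 nM to 2500 nM.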

Compound 4, half-maximal inhibitory concentration: 1100 nM
The estimate for compound 4 lay 1.1-fold (0.04 log units) below the measured number; the range from low to high includes it.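

In this assay, the change from methoxy to ethoxy on the methoxy-bearing core gives a 1.6-fold lower number from compound 3 to compound 4 (0.21 log units; within the scatter), and this agrees with the same change on the core of compound 1: the same change on two cores in this assay, a 1.9-fold lower number (0.29 log units; within the scatter) from compound 1 to compound 2 and a 1.6-fold lower number (0.21 log units; within the scatter) from compound 3 to compound 4, 1.2-fold (0.08 log units) apart, within the scatter of two such steps. Methoxy in place of hydrogen on an aromatic carbon, read on the ethoxy compounds, gives a 1.3-fold higher number from compound 2 to compound 4 (0.10 log units; within the scatter), and this also agrees with its earlier counterpart: the same change on two cores in this assay, a 1.0-fold higher number (0.01 log units; within the scatter) from compound 1 to compound 3 and a 1.3-fold higher number (0.10 log units; within the scatter) from compound 2 to compound 4, 1.2-fold (0.08 log units) apart, within the scatter of two such steps. The change therefore carries from one core to the other without a discernible difference, but every one of these steps lies within the scatter, so the data do not show that either change moves the number at all, and two cores say nothing about other cores.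

The compounds shown leave open whether a longer chain than ethoxy, such as propoxy or butoxy, would give a step beyond the scatter. They also leave open whether the ethoxy change would carry over to a core bearing an amine or a carboxylic acid in place of the added methoxy.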